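The source may report more compounds than this note shows. Statements on the series, on what has been measured and on what is new or still open speak of the compounds shown alone.

Measured compounds: compound 2, `CCc1ccc2oc(CSc3nnc(CNc4ccccc4)n3CC)nc2c1`, with 1800 nM in an assay on isolated protein for inhibition of long-chain fatty acid transport protein 1 (Mus musculus); on this read-out lower numbers stand for stronger inhibition and higher numbers for weaker inhibition. Compound 3, `CCOC(=O)c1ccc(NC(=O)CSc2nnc(CSCc3ccccc3)n2CC)cc1`, reaches only a limit of the assay, > 10000 nM. Compound 1, `CCn1c(CNc2ccccc2)nnc1SCC(=O)Nc1ccc(C(=O)OC)cc1`, has "not determined" (no result reported) in this assay.

Within the data shown here, compound 2 therefore stands alone with the only number among the three entries; one further value is a limit and one entry carries no number at all. The limit of compound 3 is the limit of > 10000 nM in this assay, at which 1 of the 3 values shown sits. Among the measured compounds shown here, no step between two measured compounds is available, so nothing measured tells how a change on the shared core moves this assay.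

Compound 4, `CC/C(=N/O)c1ccc2oc(CSc3nnc(CNc4ccccc4)n3CC)nc2c1`, differs from compound 2 by a group of 5 heavy atoms (3 carbon, 1 nitrogen, 1 oxygen; no ring) in place of a group of 2 heavy atoms (2 carbon; no ring), on an aromatic carbon. The place is an aromatic carbon of a six-membered aromatic ring of carbon only, part of a fused system of two rings, meta to a fused ring and para to a fused ring. With only compound 2 and its 1800 nM as footing, the expected step is small, in no preferred direction, and not beyond the usual scatter. Compound 4 is therefore expected to give 1800 nM, with a range from 500 nM to 7000 nM. The expected step, no change at the digits printed from compound 2 to compound 4 (within the scatter), is estimated to stay within the scatter.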

Compound 4, half-maximal inhibitory concentration: 200 nM
Beside the measured number, compound 4's estimate is 9.0-fold (0.95 log units) above it; measured number outside the range, below it.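

In this assay, the aromatic carbon para to a fused ring proves to be a place where a change registers: putting the group of 5 heavy atoms in place of ethyl gives a 9.0-fold lower number from compound 2 to compound 4 (0.95 log units; beyond the scatter). Ethyl is therefore not needed at this carbon, and a longer group without a ring, with a double bond and a hydrogen-bond donor, goes with stronger inhibition in compound 4. No measurement shown gives a reason for this step.

The compounds shown leave open whether a ketone carbonyl or a plain propyl chain at this carbon would give the same gain, so the share of the nitrogen and oxygen in the step remains unknown. Also open, on these data alone, is how an amine or a carboxylic acid would fare at this position.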